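Lengthening the Amine Side Chain of Compound 2

The source may hold more compounds than are shown below. What is called first, only, known or untested is meant among the compounds shown, and "the series" means these compounds.

Compound 1, `CN(C)CCNc1nc(-c2ccc(NC(=O)Nc3ccc(F)cc3)cc2)nc2ccsc12`, gives 390 nM in a functional assay on NCI-H460 cells (Homo sapiens) for cytotoxicity, read by MTT assay, with a stated time of 72 h; a lower number here means a stronger inhibitor, a higher number a weaker inhibitor.
Compound 2, `CN(C)CCNc1nc(-c2ccc(NC(=O)Nc3ccccc3F)cc2)nc2ccsc12`, gives 410 nM in this assay.

Of the two numbers shown, the one for compound 2 is the larger, yet the only measured step, a 1.1-fold higher number from compound 1 to compound 2 (0.02 log units; within the scatter), falls within the scatter, so the two compounds cannot be told apart on these data. That step concerns the fluorophenyl group on the urea, not the amine-bearing chain.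

Compound 3, `CCN(CC)CCCNc1nc(-c2ccc(NC(=O)Nc3ccccc3F)cc2)nc2ccsc12`, differs from compound 2 in that chain: (diethylamino)methyl in place of dimethylamino on a saturated chain carbon, two bonds along the chain from a nitrogen on an aromatic ring. Among the measured compounds shown here, no measured step touches this part of the molecule, so nothing in the data points either way. In the absence of any guide, compound 3 is expected to stay close to compound 2, with a step of a 1.1-fold higher number from compound 2 to compound 3 (0.04 log units; within the scatter) that would sit within the scatter. Compound 3 is therefore estimated at 450 nM, with a range from 150 nM to 1400 nM.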

Compound 3, half-maximal inhibitory concentration: 370 nM
Beside the measured number, compound 3's estimate is 1.2-fold (0.09 log units) above it; the measured number falls inside the stated range.
By their numbers in this assay, from the lowest: compounds 3, 1 and 2 (each within the scatter of the next).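

Among the compounds shown here, compound 3 gives the first reading on the amine-bearing chain, a part of the molecule that the fluorine step between the earlier compounds left untouched. Replacing the (2-(dimethylamino)ethyl)amino chain with the (3-(diethylamino)propyl)amino chain gives a 1.1-fold lower number from compound 2 to compound 3 (0.04 log units; within the scatter) in this assay, so this position accepts a longer chain with a bulkier amine end, and the two compounds cannot be told apart. No further measurement bears on what lies behind this result.

The added chain length and the ethyl groups on the amine arrive together here, so the compounds shown cannot separate what each contributes; a 3-(dimethylamino)propyl chain would do that. Also open is whether the chain needs an amine at its end at all, since a hydroxyl group or a carboxylic acid in that place is not among these compounds.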